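A few compounds are considered here, and "the series" means these few. Any claim that something is new, unique, unknown or untested is made for them only; others in the source may bear on it.

Series notes, three measured compounds and one open. Compound 1 `Fc1cncc(-n2ncc3cc(F)ccc32)c1` gives 456 nM in an assay on cells for inhibition of cytochrome P450 11B2, mitochondrial (Homo sapiens), read by HTRF, with stated times of 1 h and 3 h; a lower number here means a stronger inhibitor, a higher number a weaker inhibitor. Compound 2 `CC(C)(O)c1cncc(-n2ncc3ccccc32)c1` gives 15 nM in this assay. Compound 3 `Cc1nn(-c2cncc(C(C)(C)O)c2)c2ccccc12` gives 33.5 nM in this assay, the second highest of the three numbers; its nearest neighbour is compound 2, its furthest compound 1. Among the compounds with values here, the one single-point step measured so far runs a 2.2-fold higher number from compound 2 to compound 3 (0.35 log units; beyond the scatter), a methyl entering on an aromatic carbon of the five-membered ring.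

Compound 4 `CC(C)(O)c1cncc(-n2nc(C(F)(F)F)c3ccccc32)c1` continues from compound 3 with trifluoromethyl in place of methyl on an aromatic carbon, on an aromatic carbon of a five-membered aromatic ring with two nitrogen, next to the ring nitrogen, the same position touched by the step from compound 2 to compound 3. That step is the only measured one that bears on this change, and it was modest. A larger group at the same place is expected to move the number in the same direction, by a similar modest amount, though a step within the scatter cannot be ruled out. The expected step is a 1.6-fold higher number from compound 3 to compound 4 (0.22 log units; within the scatter). Compound 4 is therefore estimated at 55 nM in this assay, with a range from 18 nM to 170 nM.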

Compound 4, half-maximal inhibitory concentration: 300 nM
The estimate for compound 4 lay 5.5-fold (0.74 log units) below the measured number, and the stated range ends below it.
By their numbers in this assay, from the lowest: compound 2; then compound 3; then compounds 4 and 1 (each within the scatter of the next).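

On the aromatic carbon next to the ring nitrogen, the outcome in this assay depends strongly on which group sits there: replacing methyl with trifluoromethyl gives a much larger change (a 9.0-fold higher number from compound 3 to compound 4 (0.95 log units; beyond the scatter)) than the entry of methyl did (a 2.2-fold higher number from compound 2 to compound 3 (0.35 log units; beyond the scatter)). Against the hydrogen parent the change is large (a 20-fold higher number from compound 2 to compound 4 (1.30 log units; beyond the scatter)), so the modest methyl step gave no measure of how far this position can move the number. No measurement in hand accounts for the size of this step.

Only hydrogen, methyl and trifluoromethyl are shown on this carbon, so where an ethyl group, a chlorine, a nitrile or an amine there would fall remains open. On these data alone, whether the step from methyl to trifluoromethyl carries over to the core of compound 1 also remains open.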